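Acetal-carbon aryl variation in a thromboxane synthase inhibitor series

The source may hold more compounds than are shown below. What is called first, only, known or untested is meant among the compounds shown, and "the series" means these compounds.

Measured so far:
compound 1 `N#Cc1ccc(C2OCC(C/C=C\CCC(=O)O)C(c3cccnc3)O2)cc1` — 24 nM
compound 2 `O=C(O)CC/C=C\CC1COC(c2ccc(Cl)cc2Cl)OC1c1cccnc1` — 42 nM
compound 3 `O=C(O)CC/C=C\CC1COC(c2ccc(C(F)(F)F)cc2)OC1c1cccnc1` — 44 nM

All three share one core and differ only in the aryl group on the saturated ring carbon held between the two ring oxygens. In an assay for inhibition of Thromboxane-A synthase (Homo sapiens), using microsomes (a lower number here means a stronger inhibitor, a higher number a weaker inhibitor), compound 2 gives 42 nM and stands second highest of the three numbers; its nearest neighbour is compound 3 at a 1.0-fold higher number from compound 2 to compound 3 (0.02 log units; within the scatter) and its furthest is compound 1 at a 1.8-fold higher number from compound 1 to compound 2 (0.24 log units; within the scatter), so every measured step sits inside the scatter.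

Compound 4 `O=C(O)CC/C=C\CC1COC(c2ccc3ccccc3c2)OC1c1cccnc1` is not yet measured. It differs from compound 2 by naphthalen-2-yl in place of 2,4-dichlorophenyl on a saturated ring carbon. For the measured compounds named here, the steps that bear on this are a 1.8-fold higher number from compound 1 to compound 2 (0.24 log units; within the scatter), a 1.8-fold higher number from compound 1 to compound 3 (0.26 log units; within the scatter) and a 1.0-fold higher number from compound 2 to compound 3 (0.02 log units; within the scatter): three exchanges of the aryl group, none moving the number beyond the scatter. Nothing is known about a two-ring aryl group at this position, so the expectation rests on those three steps alone. The number for compound 4 is therefore expected to stay close to compound 2, a step of a 1.1-fold higher number from compound 2 to compound 4 (0.03 log units; within the scatter) in this assay, with no direction claimed beyond the scatter. Compound 4 is estimated at 45 nM, with a range from 15 nM to 140 nM that allows for the untested larger aryl group.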

Compound 4, half-maximal inhibitory concentration: 50 nM
Estimate against measurement, compound 4: 1.1-fold (0.05 log units) below; measured number inside the range.
By their numbers in this assay, from the lowest: compounds 1, 2, 3 and 4 (each within the scatter of the next, the first and the last beyond it).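

Naphthalen-2-yl, with 2 six-membered aromatic rings, is accepted on the saturated ring carbon between two ring oxygen atoms in this assay: compound 4 stays within the scatter of both one-ring analogues (a 1.2-fold higher number from compound 2 to compound 4 (0.08 log units; within the scatter); a 1.1-fold higher number from compound 3 to compound 4 (0.06 log units; within the scatter)). The series now has its first step at this position beyond the scatter, a modest one (a 2.1-fold higher number from compound 1 to compound 4 (0.32 log units; beyond the scatter)), although compounds 2 and 3 remain within the scatter of compound 4 and do not separate from it. No measurement available here explains these steps.

Still open, going by these compounds, is how this assay responds to a cyclohexyl group or a 4-carboxyphenyl group on this carbon. An unsubstituted phenyl group would help show whether the modest step follows the loss of the nitrile or the added aromatic ring.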